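This account rests on a few compounds, and the source may have more. Where it says the series, first, only, none or still open, it means among the compounds named here.

Measured so far in a functional assay on CWR22R cells (Homo sapiens) for antiproliferative activity, read by propidium iodide staining, with a stated time of 96 h; a lower number here means a stronger inhibitor, a higher number a weaker inhibitor
- compound 1 `CC(O)(COc1ccc(C(F)(F)F)cc1)C(=O)Nc1cccc(S(F)(F)(F)(F)F)c1` gives 3600 nM
- compound 2 `CC(O)(COc1cccc(C(F)(F)F)c1)C(=O)Nc1cccc(S(F)(F)(F)(F)F)c1` gives 28900 nM

Compound 2 has the higher number of the pair, which makes it the weaker of the two. Next is compound 3 `CC(O)(COc1ccccc1C(F)(F)F)C(=O)Nc1cccc(S(F)(F)(F)(F)F)c1`, not yet measured. It keeps the shared core and carries 2-(trifluoromethyl)phenyl in place of 3-(trifluoromethyl)phenyl on an oxygen on a saturated carbon. Among the measured compounds shown here, one measured step bears on this change: an 8.0-fold higher number from compound 1 to compound 2 (0.90 log units; beyond the scatter), with 3-(trifluoromethyl)phenyl in place of 4-(trifluoromethyl)phenyl at the same place. For the measured compounds named here, that step shows the series responds to where the trifluoromethyl group sits, but no measured compound carries 2-(trifluoromethyl)phenyl, so the direction is poorly fixed. A smaller step towards a lower number in this assay is expected, with a wide range. The expected step is a 1.6-fold lower number from compound 2 to compound 3 (0.21 log units; within the scatter). For compound 3 the estimated value is 18000 nM, with an expected range of 5000 nM to 60000 nM.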

Compound 3, half-maximal inhibitory concentration: 34900 nM
Beside the measured number, compound 3's estimate is 1.9-fold (0.29 log units) below it, and the stated range covers the measured number.
By their numbers in this assay, from the lowest: compound 1; then compounds 2 and 3 (each within the scatter of the next).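

In this assay, 2-(trifluoromethyl)phenyl in place of 3-(trifluoromethyl)phenyl gives a 1.2-fold higher number from compound 2 to compound 3 (0.08 log units; within the scatter), so these two groups on the oxygen cannot be told apart. Measured against 4-(trifluoromethyl)phenyl, the same group gives a 9.7-fold higher number from compound 1 to compound 3 (0.99 log units; beyond the scatter), which makes compound 1 the strongest of the three and shows that the earlier loss was not peculiar to 3-(trifluoromethyl)phenyl. No accompanying measurement bears on this pattern, which therefore stays purely descriptive.

As far as these compounds go, whether a nitrile or a chlorine in place of the trifluoromethyl group of compound 1 would hold its potency remains open. From the compounds shown here alone, it is also open whether an unsubstituted phenyl on the same oxygen would group with compound 1 or with compounds 2 and 3.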